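Changing the aryl amine substituent on a weak growth inhibitor

The source may report more compounds than this note shows. Statements on the series, on what has been measured and on what is new or still open speak of the compounds shown alone.

Measured in a functional assay on HepG2 cells (Homo sapiens) for antiproliferative activity, read by spectrophotometry, with a stated time of 2 days; a lower number here means a stronger inhibitor of growth, a higher number a weaker inhibitor of growth:
compound 1 `CN(c1cccc2c1CN(c1nc(Nc3cc(C(F)(F)F)cc(C(F)(F)F)c3)ncc1C(F)(F)F)C2)S(C)(=O)=O`, 10300 nM
compound 2 `Cc1cc(Cl)ccc1Nc1ncc(C(F)(F)F)c(N2Cc3cccc(N(C)S(C)(=O)=O)c3C2)n1`, 19600 nM
compound 3 `CN(c1cccc2c1CN(c1nc(Nc3ccc(C(F)(F)F)cc3)ncc1C(F)(F)F)C2)S(C)(=O)=O`, > 30000 nM, which is a limit of the assay and not a number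

Compound 2 has the highest of the two numbers, and compound 1 sits within the scatter of it. Compound 4 `CN(c1cccc2c1CN(c1nc(Nc3ccc(Cl)c(C(F)(F)F)c3)ncc1C(F)(F)F)C2)S(C)(=O)=O` arises from compound 2 by 4-chloro-3-(trifluoromethyl)phenyl in place of 4-chloro-2-methylphenyl on a nitrogen on an aromatic ring. Within the data shown here, the one measured step at this position is an at least 1.5-fold higher number from compound 2 to compound 3 (0.18 log units; that floor lies within the scatter), pointing toward a weaker inhibitor, though its floor lies within the scatter. Compound 3 reached (the limit of > 30000 nM in this assay, at which 1 of the 3 values shown sits). For compound 4 a step of a 1.3-fold higher number from compound 2 to compound 4 (0.11 log units; within the scatter) is therefore expected, toward a weaker inhibitor and possibly to the limit. Compound 4 is estimated at 25000 nM, between 9000 nM and 60000 nM.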

Compound 4, concentration for 50% growth inhibition: 16000 nM
Compound 4: middle estimate off by 1.6-fold (0.19 log units), on the high side; low and high end bracket the measured number.
By their numbers in this assay, from the lowest: compounds 1, 4 and 2 (each within the scatter of the next). At a limit, above all of these: compound 3.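

In this assay, 4-chloro-3-(trifluoromethyl)phenyl on this nitrogen gives a 1.2-fold lower number from compound 2 to compound 4 (0.09 log units; within the scatter), so this exchange of aryl groups leaves the number unchanged within the scatter. Set against the other trifluoromethyl-bearing ring, the same group gives an at least 1.8-fold lower number from compound 3 to compound 4 (0.27 log units; that floor lies within the scatter), so the true size of this step remains unknown. Compound 3 has a limit and not a number: the limit of > 30000 nM in this assay, at which 1 of the 4 values shown sits.

From the compounds shown here alone, it remains open whether any group at this position can lower the number beyond the scatter. A phenyl ring carrying an amine or a carboxylic acid would test this.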